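Nitro for chloro in the oxadiazole-linked sugar series

The compounds below may be only part of what the source reports. "The series", "measured", "known", "first", "only" and "open" are said of these compounds alone.

Measured so far in a functional assay on T47D cells (Homo sapiens) for antiproliferative activity, read by sulforhodamine B assay, with a stated time of 48 h; on this read-out lower numbers stand for stronger inhibition of growth and higher numbers for weaker inhibition of growth:
compound 1 `COc1cc(-c2cc(CO[C@@H]3O[C@H](CSc4ncn[nH]4)[C@H]4OC5(CCCC5)O[C@@H]34)on2)cc(OC)c1OC` — 94000 nM
compound 2 `Nc1nnc(SC[C@H]2O[C@@H](OCc3noc(-c4ccc(Cl)cc4)n3)[C@@H]3OC4(CCCC4)O[C@@H]32)s1` — 18000 nM
compound 3 `CC1(C)O[C@H]2[C@H](OCc3noc(-c4ccc([N+](=O)[O-])cc4)n3)O[C@H](CSc3ncn[nH]3)[C@H]2O1` — a limit, > 100000 nM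

Compound 2 holds the lowest of the two numbers given in this assay; the nearest number belongs to compound 1, which sits higher by a margin beyond the usual scatter. For compound 3 this assay reports only a limit, > 100000 nM, and no number. the limit of > 100000 nM in this assay, at which 1 of the 3 values shown sits.

Compound 4 `Nc1nnc(SC[C@H]2O[C@@H](OCc3noc(-c4ccc([N+](=O)[O-])cc4)n3)[C@@H]3OC4(CCCC4)O[C@@H]32)s1` is not yet measured. It differs from compound 2 in one place: nitro in place of chloro on an aromatic carbon, read one bond further out as 4-chlorophenyl to 4-nitrophenyl.

For the measured compounds named here, no step between measured compounds connects these two directly. Compound 3 carries the same 4-nitrophenyl group on a differently protected core and reaches only the limit, whereas compound 2 with 4-chlorophenyl gives a number; the step from compound 2 to compound 4 is therefore expected to go toward weaker inhibition, by a 3.1-fold higher number from compound 2 to compound 4 (0.49 log units; beyond the scatter), beyond the scatter. For compound 4 the estimate in this assay is 55000 nM, with a range from 18000 nM to 160000 nM.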

Compound 4, concentration for 50% growth inhibition: 19000 nM
Compound 4: middle estimate off by 2.9-fold (0.46 log units), on the high side; the range from low to high includes it.
By their numbers in this assay, from the lowest: compounds 2 and 4 (each within the scatter of the next); then compound 1. At a limit, above all of these: compound 3.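

In this assay, for the compounds shown here, the change from chloro to nitro at this position reads as a 1.1-fold higher number from compound 2 to compound 4 (0.02 log units; within the scatter), the first direct comparison. Going by these compounds alone, on the aromatic carbon para to a large group, the larger nitro, with its 3 heavy atoms and 2 hydrogen-bond acceptors, therefore takes the place of the single chlorine with no change in growth inhibition beyond the scatter. Compound 3 carries the same 4-nitrophenyl group but differs from compound 4 in more than one place, so its value, which is a limit and not a number, cannot be read as an effect of nitro: the limit of > 100000 nM in this assay, at which 1 of the 4 values shown sits.

This single pair does not show whether the same parity between chloro and nitro would hold on the core of compound 1 or compound 3. It also leaves open how the read-out would respond to an amine, a carboxylic acid or a longer alkyl chain at the same position on the phenyl ring, and whether any such group would separate from compound 2 by more than the scatter.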